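The source may report more compounds than this note shows. Statements on the series, on what has been measured and on what is new or still open speak of the compounds shown alone.

Compound 1 `CN(C)CCCNc1nc(-c2ccc(NC(=O)Nc3ccc(Cl)cc3)cc2)nc2c(Cl)c(Cl)sc12` gives 330 nM in a functional assay on HT-29 cells (Homo sapiens) for cytotoxicity, read by MTT assay, with a stated time of 72 h (on this read-out higher numbers stand for weaker inhibition and lower numbers for stronger inhibition), the lowest of the three numbers seen so far. Compound 3 `CN(C)CCNc1nc(-c2ccc(NC(=O)Nc3ccc(F)cc3)cc2)nc2ccsc12` gives 350 nM in this assay, which sits within the scatter of compound 1, so the two cannot be ranked against each other. Compound 2 `CN(C)CCCNc1nc(-c2ccc(NC(=O)Nc3ccc(Cl)cc3Cl)cc2)nc2ccsc12` gives 1860 nM in this assay, a number clearly higher than that of compound 1 and beyond the scatter. Compound 4 `Cc1ccc(NC(=O)Nc2ccc(-c3nc(NCCCN(C)C)c4sc(Cl)c(Cl)c4n3)cc2)cc1` has not yet been measured. It differs from compound 1 in one place: methyl in place of chloro on an aromatic carbon. Within the data shown here, no measured pair shows this exact swap, so the expected step in this assay is small, with no change beyond the scatter likely in either direction. Compound 4 is therefore estimated at 420 nM, with a range from 150 nM to 1200 nM, meaning an expected step of a 1.3-fold higher number from compound 1 to compound 4 (0.10 log units; within the scatter).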

Compound 4, half-maximal inhibitory concentration: 1320 nM
Beside the measured number, compound 4's estimate is 3.1-fold (0.50 log units) below it, outside the stated range (above it).
By their numbers in this assay, from the lowest: compounds 1 and 3 (each within the scatter of the next); then compounds 4 and 2 (each within the scatter of the next).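

Exchanging 4-chlorophenyl for 4-methylphenyl changes one heavy atom and alters no ring, hydrogen-bond donor, hydrogen-bond acceptor or net charge, yet in this assay it gives a 4.0-fold higher number from compound 1 to compound 4 (0.60 log units; beyond the scatter). This first one-place comparison shows that this position is sensitive to such a small exchange, with chloro giving the lower number of the two. Nothing available explains the difference.

Still open, on these data alone, is how methoxy, trifluoromethyl or a plain hydrogen at this same place would compare with chloro and methyl. It is also unknown whether the step would hold with a different amine chain.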